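3-Methylphenyl for 2-Fluorophenyl on an Aromatic Nitrogen

The source may hold more compounds than are shown below. What is called first, only, known or untested is meant among the compounds shown, and "the series" means these compounds.

- Compound 1 `COc1cc(C(=O)c2cn(-c3ccccc3)cc2-c2cccc(F)c2)cc(OC)c1OC` gives 57 nM
- Compound 2 `COc1cc(C(=O)c2cn(-c3ccccc3F)cc2-c2ccccc2)cc(OC)c1OC` gives 85 nM

Both compounds were measured in a functional assay on MCF7 cells (Homo sapiens) for inhibition, read by trypan blue exclusion, with a stated time of 3 days (a lower number here means a stronger inhibitor, a higher number a weaker inhibitor), and their two values lie within the usual scatter of each other. Among the compounds with values here, compound 2 therefore cannot be told apart from compound 1, the only other compound with a number so far.

Compound 3 `COc1cc(C(=O)c2cn(-c3cccc(C)c3)cc2-c2ccccc2)cc(OC)c1OC` keeps the shared core of compound 2 and changes a single group: 3-methylphenyl in place of 2-fluorophenyl on an aromatic nitrogen. Within the data shown here, no two measured compounds differ in one place only, so the data offer no direct guide to this swap. The only anchors are the two measured values, which sit close together, and so no change beyond the scatter is expected in this assay for this swap. The estimate is a 1.1-fold lower number from compound 2 to compound 3 (0.03 log units; within the scatter) and it is a cautious expectation with a wide margin. Compound 3 is expected to give 80 nM (estimated range 25 nM to 250 nM).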

Compound 3, half-maximal inhibitory concentration: 120 nM
Beside the measured number, compound 3's estimate is 1.5-fold (0.18 log units) below it, and the stated range covers the measured number.
By their numbers in this assay, from the lowest: compounds 1, 2 and 3 (each within the scatter of the next, the first and the last beyond it).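

Within the data shown here, this is the first direct reading of a change on the aromatic nitrogen: in this assay, 3-methylphenyl in place of 2-fluorophenyl gives a 1.4-fold higher number from compound 2 to compound 3 (0.15 log units; within the scatter), so the two compounds cannot be told apart. For these two groups, then, the position shows no difference that this measurement can resolve, even though fluorine gives way to a methyl group and the number in the group's name changes as well. Nothing measured beyond these cell values helps to explain why the two groups read alike.

A single step changes both the substituent and its numbered place on the phenyl ring, so the compounds shown cannot separate those two changes, and they cover only two phenyl groups of the same size, with no hydrogen-bond donors or acceptors and no net charge. From the compounds shown here alone, whether the position would tolerate a phenyl ring carrying an amine or a carboxylic acid, or a longer carbon chain in place of the ring, remains open.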